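Methoxyphenyl swap on the shared core

A few compounds are considered here, and "the series" means these few. Any claim that something is new, unique, unknown or untested is made for them only; others in the source may bear on it.

In a functional assay on A549 cells (Homo sapiens) for antiproliferative activity, read by MTT assay, with a stated time of 72 h (a higher number here means a weaker inhibitor, a lower number a stronger inhibitor), compound 1 (`COc1cccc(Nc2nc3c(c(Oc4cccc(NC(=O)C=C(C)C)c4)n2)CSCC3)c1`) gives 19800 nM and compound 2 (`C=C(F)C(=O)Nc1cccc(Oc2nc(Nc3cccc(OC)c3)nc3c2CSCC3)c1`) gives 29600 nM with the two numbers inside the scatter of each other, so compound 1 has no distinct standing yet. Compound 3 (`COc1ccc(Nc2nc3c(c(Oc4cccc(NC(=O)C=C(C)C)c4)n2)CSCC3)cc1`) has 4-methoxyphenyl in place of the 3-methoxyphenyl of compound 1 on a nitrogen on an aromatic ring (4-methoxyphenyl in place of 3-methoxyphenyl on a nitrogen on an aromatic ring) while the rest stays the same. Among the compounds with values here, the only measured step is a 1.5-fold higher number from compound 1 to compound 2 (0.17 log units; within the scatter) and it lies on a carbonyl carbon, so no measured step tests a change at this nitrogen. With so little to go on, no shift beyond the scatter is expected in either direction. For compound 3 the expected step is a 1.0-fold higher number from compound 1 to compound 3 (0.00 log units; within the scatter) in this assay as a working assumption. Compound 3 is estimated at 20000 nM with an expected range from 8000 nM to 50000 nM for now.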

Compound 3, half-maximal inhibitory concentration: 26900 nM
Compound 3: middle estimate off by 1.3-fold (0.13 log units), on the low side, within the range that was stated.
By their numbers in this assay, from the lowest: compounds 1, 3 and 2 (each within the scatter of the next).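

In this assay, within the data shown here, the swap of 3-methoxyphenyl for 4-methoxyphenyl on a nitrogen on an aromatic ring gives a step within the scatter (a 1.4-fold higher number from compound 1 to compound 3 (0.13 log units; within the scatter)), and this is the only step that tests this nitrogen. Where the methoxy sits on this phenyl therefore does not separate compound 1 from compound 3 in this assay, and the two groups have the same atom and acceptor counts. Nothing available bears on why the two read alike.

On these data alone, it remains open whether a different group at this nitrogen, such as a phenyl carrying an amine or a carboxylic acid, or a longer chain in place of the methoxy, would give a step beyond the scatter. Also open, as far as these compounds go, is whether the 4-methoxyphenyl swap reads the same with the 1-fluoroethenyl amide of compound 2.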